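Urea aryl swap on the shared core: thiophene for dimethylphenyl

The source may hold more compounds than are shown below. What is called first, only, known or untested is meant among the compounds shown, and "the series" means these compounds.

Compound 2 `Cc1cc(C)cc(NC(=O)Nc2ccc(Nc3ncnc4c3OCCN4)cc2)c1` gives 971 nM in an assay on isolated protein for inhibition of proto-oncogene tyrosine-protein kinase receptor Ret variant V804M (Homo sapiens), read by 33P incorporation, with stated times of 15 min and 40 min (on this read-out higher numbers stand for weaker inhibition and lower numbers for stronger inhibition), the lower of the pair measured; compound 1 `O=C(Nc1ccc(Cl)cc1)Nc1ccc(Nc2ncnc3c2OCCN3)cc1` gives 2280 nM. Among the compounds with values here, the one step known, a 2.3-fold lower number from compound 1 to compound 2 (0.37 log units; beyond the scatter), shows that the aryl group on the urea nitrogen moves the number modestly. Compound 3 `O=C(Nc1ccc(Nc2ncnc3c2OCCN3)cc1)Nc1cccs1` carries thiophen-2-yl in place of 3,5-dimethylphenyl on an amide-type nitrogen. Within the data shown here, no measured step covers a thiophene at this position, so only the size of the step from compound 1 to compound 2 guides the expectation: a modest shift, direction uncertain, a 1.5-fold higher number from compound 2 to compound 3 (0.19 log units; within the scatter) taken as a slight weakening. Compound 3 is expected at 1500 nM, within 600 nM to 4000 nM.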

Compound 3, half-maximal inhibitory concentration: 8640 nM
Compound 3: middle estimate off by 5.8-fold (0.76 log units), on the low side; the measured number lies above the stated range.
By their numbers in this assay, from the lowest: compound 2; then compound 1; then compound 3.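

Within the data shown here, on the amide-type nitrogen, an 8.9-fold higher number from compound 2 to compound 3 (0.95 log units; beyond the scatter) and a 3.8-fold higher number from compound 1 to compound 3 (0.58 log units; beyond the scatter) put thiophen-2-yl behind both substituted phenyl groups in this assay and mark the largest change at this position so far. Among these three compounds, replacing the phenyl ring moves the number further than exchanging one substituted phenyl group for the other. Nothing measured here accounts for the weakening. Open, on these data alone, is whether an unsubstituted phenyl, a pyridin-3-yl or a thiophene bearing methyl groups on the same nitrogen would rank with the phenyl pair or with compound 3.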